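Triazole Sulfonamides in Gastric Cancer Cells: A Chlorophenyl Variant

A few compounds are considered here, and "the series" means these few. Any claim that something is new, unique, unknown or untested is made for them only; others in the source may bear on it.

Compound 1 `O=c1[nH]cc(S(=O)(=O)Nc2ccccc2-c2cn(-c3ccccc3Cl)nn2)c(=O)[nH]1`: 6520 nM
Compound 2 `Cc1ccccc1-n1cc(-c2cccc(NS(=O)(=O)c3c[nH]c(=O)[nH]c3=O)c2)nn1`: 9230 nM

Both compounds were tested in a functional assay on SGC-7901 cells (Homo sapiens) for antiproliferative activity, read by MTT assay, with a stated time of 24 h; on this read-out lower numbers stand for stronger inhibition and higher numbers for weaker inhibition. In this assay compound 1 gives 6520 nM, and compound 2 gives 9230 nM; the two numbers lie within the scatter of each other, so compound 2 cannot be set apart from compound 1. Compound 3 `O=c1[nH]cc(S(=O)(=O)Nc2cccc(-c3cn(-c4ccc(Cl)cc4)nn3)c2)c(=O)[nH]1` has not yet been measured. It differs from compound 2 by 4-chlorophenyl in place of 2-methylphenyl on an aromatic nitrogen. Among the measured compounds shown here, no measured step of this kind exists here, so a change within the scatter, or only slightly beyond it, is expected, with no clear direction. Compound 3 is therefore estimated at 7500 nM, in a range from 3000 nM to 18000 nM, which would mean an expected step of a 1.2-fold lower number from compound 2 to compound 3 (0.09 log units; within the scatter) in this assay.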

Compound 3, half-maximal inhibitory concentration: 2160 nM
The estimate for compound 3 lay 3.5-fold (0.54 log units) above the measured number; measured number outside the range, below it.
By their numbers in this assay, from the lowest: compound 3; then compounds 1 and 2 (each within the scatter of the next).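

In this assay, among the compounds shown here, 4-chlorophenyl in place of 2-methylphenyl on the aromatic nitrogen gives a 4.3-fold lower number from compound 2 to compound 3 (0.63 log units; beyond the scatter) and is the first measured change at this position. The position thus responds to the choice of aryl group, although the two groups match in heavy atoms and carry no hydrogen-bond donors or acceptors. Nothing measured here accounts for this step.

The compounds shown leave open whether the chlorine or the absence of the methyl matters. An unsubstituted phenyl or a 4-methylphenyl on this nitrogen would separate the two.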